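Removing the aryl group from the ring nitrogen of compound 2

The source may hold more compounds than are shown below. What is called first, only, known or untested is meant among the compounds shown, and "the series" means these compounds.

Two compounds built on the same core have been examined in a functional assay on ileum for inhibition of histamine H1 receptor (Cavia porcellus); on this read-out lower numbers stand for stronger inhibition and higher numbers for weaker inhibition. Compound 1 `CCCCN1CCN(c2nc3ccccc3n2CCOCC)CC1` carries a butyl group on its piperazine and an ethoxyethyl chain on the ring nitrogen of the core; in this assay compound 1 gives 15 nM. Compound 2 `CN1CCN(c2nc3ccccc3n2-c2ccccc2)CC1` carries a methyl group on the piperazine and a phenyl group on the ring nitrogen; in this assay compound 2 gives 760 nM, the highest of the two numbers, and its gap to compound 1 lies well beyond the scatter. The two compounds differ in more than one place, so nothing is attributed to either change on its own.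

Compound 3 `CN1CCN(c2nc3ccccc3[nH]2)CC1` differs from compound 2 by hydrogen in place of phenyl on an aromatic nitrogen. Among the compounds with values here, no measured pair shows this kind of change, so the expected size of the step is uncertain. Both measured compounds carry a substituent on that ring nitrogen, and compound 2 already sits at the weak end of the pair; compound 3, which carries none, is expected to be weaker still, with an estimated step of a 3.3-fold higher number from compound 2 to compound 3 (0.52 log units; beyond the scatter). In this assay compound 3 is therefore expected to give about 2500 nM, with a range from 500 nM to 12000 nM.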

Compound 3, half-maximal inhibitory concentration: > 3000 nM
Compound 3 ended at the assay's limit; the forecaster's own chance of this, stated with the estimate: 15%; middle value at least 1.2-fold (0.07 log units) from the limit.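

Within the data shown here, compound 2 and compound 3 differ only on this aromatic nitrogen, so this pair gives the first direct reading of the position, which the gap between compound 1 and compound 2 could not provide. In this assay, hydrogen in place of phenyl gives an at least 3.9-fold higher number from compound 2 to compound 3 (0.59 log units; beyond the scatter), so a phenyl group on this nitrogen gives stronger inhibition than no substituent, even though compound 2 is itself the weaker of the first two compounds. The value of compound 3, > 3000 nM, is a limit of the assay and not a number, and the full size of the step remains unknown because the reading stops at that limit: the limit of > 3000 nM in this assay, at which 1 of the 3 values shown sits.

The compounds shown do not separate how much of the gap between compound 1 and compound 2 belongs to the group on this nitrogen and how much to the group on the piperazine. They also leave open how a benzyl group or a simple ethyl chain on this nitrogen would compare with phenyl and with the ethoxyethyl chain of compound 1.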